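The source may hold more compounds than are shown below. What is called first, only, known or untested is meant among the compounds shown, and "the series" means these compounds.

Compound 1: `ClCc1ccc(Cn2cnc3c(Cl)ncnc32)cc1`, 1230 nM in a functional assay on UACC-62 cells (Homo sapiens) for cytotoxicity, read by sulforhodamine B assay, with a stated time of 48 h; on this read-out lower numbers stand for stronger inhibition of growth and higher numbers for weaker inhibition of growth.
Compound 2: `ClCc1ccccc1Cn1cnc2ncnc(Cl)c21`, 1860 nM.
Compound 3: `ClCc1ccc(Cn2cnc3c(Cl)nc(Cl)nc32)cc1`, 2040 nM.

Of the compounds shown here, three have been measured in this assay, and a fourth, compound 4, `ClCc1ccccc1Cn1cnc2nc(Cl)nc(Cl)c21`, has not yet been tested. Compound 1 and compound 3 share a core and differ in one place: chloro in place of hydrogen on an aromatic carbon. That change gave a 1.7-fold higher number from compound 1 to compound 3 (0.22 log units; within the scatter), so the two numbers sit within the range that repeat measurements of this kind usually cover. Compound 2 has the same atoms as compound 1 joined differently; the difference between the two cores is not broken down here. Compound 2 and compound 3 give numbers close to each other, and compound 1 is not far from either of them.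

Compound 4 relates to compound 2 as compound 3 relates to compound 1: chloro in place of hydrogen on an aromatic carbon. The surroundings of the change are described in the same words in both pairs, so it is the same change made on another core. Only one earlier example of it exists among these compounds, so the expectation rests on that single step and carries the uncertainty of a small set. Compound 4 is expected to come out at 2900 nM. Among the compounds with values here, the expected step, a 1.6-fold higher number from compound 2 to compound 4 (0.19 log units; within the scatter), is taken to match the measured 1.7-fold higher number from compound 1 to compound 3 (0.22 log units; within the scatter), since that is the only earlier example of this change. For compound 4 the expected span runs from 1500 nM to 6000 nM.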

Compound 4, concentration for 50% growth inhibition: 1200 nM
Compound 4: middle estimate off by 2.4-fold (0.38 log units), on the high side; the whole stated range lies above it.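

In this assay, putting chloro in place of hydrogen on an aromatic carbon of the core of compound 2 gave a 1.6-fold lower number from compound 2 to compound 4 (0.19 log units; within the scatter), so this step is no larger than the differences seen between repeat measurements. The printed direction is opposite to that of the earlier step, but this does not show that the two cores respond differently, since the gap between the steps is also no larger than such scatter allows: the same change on two cores in this assay, a 1.7-fold higher number (0.22 log units; within the scatter) from compound 1 to compound 3 and a 1.6-fold lower number (0.19 log units; within the scatter) from compound 2 to compound 4, 2.6-fold (0.41 log units) apart, within the scatter of two such steps. What the two pairs do show is that this change gave no step beyond the scatter on either core; they do not show that it has no effect, or that its effect is the same on both cores, as steps this small cannot settle either point.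

The compounds shown carry only hydrogen or chloro on this aromatic carbon between two ring nitrogen atoms, so it remains open whether an amine, a carboxylic acid or a longer chain there would give a step beyond the scatter. As far as these compounds go, two pairs are also a small base, and whether the step stays this small on a third core remains open too.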